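The source may hold more compounds than are shown below. What is called first, only, known or untested is meant among the compounds shown, and "the series" means these compounds.

Measured in a functional assay on HCT-116 cells (Homo sapiens) for cytotoxicity, read by MTT assay, with a stated time of 72 h; on this read-out higher numbers stand for weaker inhibition and lower numbers for stronger inhibition:
- compound 1 `COc1ncc(-c2ccc3nc(NC(=O)N4CCCC4)nn3c2)cc1NS(=O)(=O)c1ccc(F)cc1`: 1290 nM
- compound 2 `COc1ncc(-c2ccc3nc(NC(=O)NCCN4CCCC4)nn3c2)cc1NS(=O)(=O)c1ccc(F)cc1`: 230 nM
- compound 3 `COc1ncc(-c2ccc3nc(NC(=O)NCCN4CCN(C)CC4)nn3c2)cc1NS(=O)(=O)c1ccc(F)cc1`: 260 nM

Compound 3 cannot be told apart from compound 2, as the step is a 1.1-fold higher number from compound 2 to compound 3 (0.05 log units; within the scatter). The gap to the remaining measured compound is much clearer: a 5.0-fold lower number from compound 1 to compound 3 (0.70 log units; beyond the scatter). A similar gap appears as a 5.6-fold lower number from compound 1 to compound 2 (0.75 log units; beyond the scatter). Compound 3 therefore sits with compound 2 at the low, stronger end of this small set.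

Compound 4 `CNC(=O)Nc1nc2ccc(-c3cnc(OC)c(NS(=O)(=O)c4ccc(F)cc4)c3)cn2n1` cuts the long side chain back: hydrogen in place of (4-methylpiperazin-1-yl)methyl on a saturated chain carbon bound to an amide-type nitrogen. Hydrogen takes the place of (4-methylpiperazin-1-yl)methyl on a saturated chain carbon bound to an amide-type nitrogen, so 2-(4-methylpiperazin-1-yl)ethyl becomes methyl.

Within the data shown here, no measured step makes exactly this change. The closest evidence is the two steps from compound 1, which also lacks the long chain, although it carries pyrrolidin-1-yl on the carbonyl carbon instead of methylamino. Those steps suggest that losing the chain should raise the number, by a modest amount and perhaps by less than those gaps. Expected in this assay is a 2.7-fold higher number from compound 3 to compound 4 (0.43 log units; beyond the scatter). For compound 4 the estimated value is 700 nM, with an expected range from 200 nM to 2500 nM.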

Compound 4, half-maximal inhibitory concentration: 180 nM
Compound 4: the middle estimate sits 3.9-fold (0.59 log units) above what was measured, and the stated range ends above it.
By their numbers in this assay, from the lowest: compounds 4, 2 and 3 (each within the scatter of the next); then compound 1.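

In this assay the long side chain turns out not to be needed at this position: cutting 2-(4-methylpiperazin-1-yl)ethyl back to methyl gives a 1.4-fold lower number from compound 3 to compound 4 (0.16 log units; within the scatter) and cutting the matching pyrrolidine chain back to methyl gives a 1.3-fold lower number from compound 2 to compound 4 (0.11 log units; within the scatter) and so neither step can be told from repeat-measurement noise. The first three compounds alone left room to credit the chain for the gap between compound 1 and compounds 2 and 3, yet methylamino with no ring or long chain also gives a 7.2-fold lower number from compound 1 to compound 4 (0.86 log units; beyond the scatter) as a clear step. Among these four compounds, the one that stands apart is therefore the one with pyrrolidin-1-yl on the carbonyl carbon, while the three with a substituted amino group there cannot be separated.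

No measurement here offers a reason for this difference. From the compounds shown here alone, it also remains open whether a plain amino group, an ethylamino group or a chain ending in a carboxylic acid on the same carbonyl carbon would keep the number in this low range.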